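This account rests on a few compounds, and the source may have more. Where it says the series, first, only, none or still open, it means among the compounds named here.

Working notes on the sulfonamide series.

Three members share one core and differ only in the group on the sulfonamide nitrogen. Compound 1 `O=S(=O)(Nc1cccc2ccccc12)c1ccc2nc(-c3ccccc3)c(-c3ccccc3)nc2c1` carries naphthalen-1-yl there; in an ADME assay on the whole organism for pharmacokinetics, with Homo sapiens as the target (on this read-out higher numbers stand for higher oral bioavailability and lower numbers for lower oral bioavailability), compound 1 gives 100%. Compound 2 `O=S(=O)(Nc1ccc(Cl)cc1)c1ccc2nc(-c3ccccc3)c(-c3ccccc3)nc2c1` carries 4-chlorophenyl, and in this assay compound 2 gives 100%. Compound 3 `O=S(=O)(Nc1ccc2ccccc2c1)c1ccc2nc(-c3ccccc3)c(-c3ccccc3)nc2c1` carries naphthalen-2-yl, and in this assay compound 3 gives 100%. The three steps among them are flat: no change at the digits printed from compound 1 to compound 2 (within the scatter), no change at the digits printed from compound 1 to compound 3 (within the scatter) and no change at the digits printed from compound 2 to compound 3 (within the scatter). Compound 3 therefore stands level with compounds 1 and 2, with no separation at the digits shown.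

The next member, compound 4 `Cc1ccnc(NS(=O)(=O)c2ccc3nc(-c4ccccc4)c(-c4ccccc4)nc3c2)c1`, is reached from compound 3 by one change: 4-methylpyridin-2-yl in place of naphthalen-2-yl on a sulfonamide nitrogen. Every step measured so far swaps the group on that nitrogen, and each of them (no change at the digits printed from compound 1 to compound 2 (within the scatter); no change at the digits printed from compound 2 to compound 3 (within the scatter)) left this assay unchanged within the scatter. Going by the values given here, those steps exchange carbon-only rings among themselves; none brings in a ring with a hetero atom, so the bearing of the earlier steps on this one is indirect. On the evidence of the flat steps, no movement beyond the scatter is expected, and compound 4 is estimated at 95%, range 80% to 100%, which corresponds to an expected step of a number 5 percentage points lower from compound 3 to compound 4 (within the scatter).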

Compound 4, oral bioavailability: 100%
Compound 4: middle estimate off by 5 percentage points, on the low side; the range from low to high includes it.
By their numbers in this assay, from the lowest: compounds 1, 2, 3 and 4 (each within the scatter of the next).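

The series now has a ring with a hetero atom on the sulfonamide nitrogen: 4-methylpyridin-2-yl replaces naphthalen-2-yl, so one six-membered aromatic ring with 1 hydrogen-bond acceptor takes the place of 2 carbon-only rings with none, and in this assay the step reads no change at the digits printed from compound 3 to compound 4 (within the scatter). The two other comparisons agree, with no change at the digits printed from compound 2 to compound 4 (within the scatter) and no change at the digits printed from compound 1 to compound 4 (within the scatter), so the flat picture at this position is no longer confined to carbon-only rings and holds for all four listed compounds. No measured property is available to explain this flat result.

On these data alone, every group on the sulfonamide nitrogen so far is an aromatic ring, so it remains open how this assay responds there to a saturated ring such as piperidine, a longer alkyl chain or an aromatic ring bearing a carboxylic acid. The shared core is also identical in all four compounds, leaving open whether changes to it would separate members of the series in this assay.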